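This account rests on a few compounds, and the source may have more. Where it says the series, first, only, none or still open, it means among the compounds named here.

Of the compounds shown here, two of a shared core have been tested so far. Compound 1 `Nc1cc(N)c2nc(-c3ccccc3)c(Oc3ccc(Cl)c(Cl)c3)nc2c1` was measured in a functional assay on OVCAR-3 cells (Homo sapiens) for inhibition, read by sulforhodamine B assay, with a stated time of 48 h (on this read-out higher numbers stand for lower toxicity in this test and lower numbers for higher toxicity in this test), and gives 66100 nM. Compound 2 `COc1ccc(CNc2nc3cc(N)cc(N)c3nc2-c2ccccc2)cc1` differs from it elsewhere on the core and in this assay gives 38900 nM. These two numbers lie within the usual scatter of each other, so neither compound can be called the less toxic of the pair on this evidence.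

Compound 3 `Nc1cc(N)c2nc(-c3ccccc3)c(Sc3ccc(F)cc3)nc2c1` has not been measured. It differs from compound 1 in one place: (4-fluorophenyl)sulfanyl in place of 3,4-dichlorophenoxy on an aromatic carbon. For the measured compounds named here, no measured pair in this set shows a change of this kind, so there is nothing to say how large a step it should bring. With both known values sitting close together, the expected step from compound 1 to compound 3 is a 1.3-fold lower number from compound 1 to compound 3 (0.12 log units; within the scatter), that is, none beyond the scatter. Compound 3 is therefore estimated at 50000 nM in this assay, within a range from 15000 nM to 160000 nM.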

Compound 3, concentration lethal to 50% of the cells: 69200 nM
The estimate for compound 3 lay 1.4-fold (0.14 log units) below the measured number; measured number inside the range.
By their numbers in this assay, from the lowest: compounds 2, 1 and 3 (each within the scatter of the next).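

For the compounds shown here, replacing 3,4-dichlorophenoxy with (4-fluorophenyl)sulfanyl on this aromatic carbon gives a 1.0-fold higher number from compound 1 to compound 3 (0.02 log units; within the scatter) in this assay, the first measured pair for this position. Here, the atom joining the outer ring to the core and the halogens on that ring differ together, yet the step stays within the scatter, so this single exchange leaves the read-out effectively unmoved. Since the two differences are measured only together, their separate contributions cannot be read, and nothing measured on these groups explains the result.

As far as these compounds go, it remains open whether a group without an outer aromatic ring, such as a carboxylic acid or a longer alkyl chain, would produce a step beyond the scatter at this position. The sulfur-linked and oxygen-linked versions carrying the same ring substituents would separate the linker from the halogens.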